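Removing a chloro group from a limit-bound benzamide

The source may report more compounds than this note shows. Statements on the series, on what has been measured and on what is new or still open speak of the compounds shown alone.

Compound 1 `COc1ccccc1C(=O)Nc1ccc(Sc2nc3ccccc3s2)cc1` — > 100000 nM
Compound 2 `COc1ccccc1C(=O)Nc1ccc(Sc2nc3ccccc3s2)c(Cl)c1` — > 100000 nM
Compound 3 `O=C(Nc1cccc(Cl)c1)c1cccc(Br)c1O` — > 100000 nM

In an assay on isolated protein for inhibition of thiosulfate sulfurtransferase (Homo sapiens), with a stated time of 60 min, in the absence of a further agent (on this read-out higher numbers stand for weaker inhibition and lower numbers for stronger inhibition), compound 1 gives > 100000 nM, which is a limit of the assay and not a number. Compound 2 gives > 100000 nM, again only a limit. Compound 3 gives > 100000 nM, also a limit. The change hydrogen in place of chloro on an aromatic carbon gives a step that the two limits leave unreadable from compound 2 to compound 1, unreadable because the limit of > 100000 nM in this assay, at which 3 of the 3 values shown sit, holds both ends of it. The difference between the core of compound 2 and that of compound 3 is not broken down here. For the measured compounds named here, compound 4 `O=C(Nc1ccccc1)c1cccc(Br)c1O` differs from compound 3 by hydrogen in place of chloro on an aromatic carbon; this is the same kind of change as the one from compound 2 to compound 1, not the same, since there the place was also ortho to a large group. With compound 3 at the limit and the earlier step unreadable, compound 4 is expected to give 150000 nM, between 30000 nM and 600000 nM. The expected step is a step that the limit leaves unreadable from compound 3 to compound 4, resting on what compound 3 gives, > 100000 nM.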

Compound 4, half-maximal inhibitory concentration: > 100000 nM
Compound 4 gave a limit, no number; the forecaster's own chance of this, stated with the estimate: 85%; the middle value lies beyond the limit too.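

The step from compound 3 to compound 4 cannot be read, because both compounds sit at the same limit, which is not a number: the limit of > 100000 nM in this assay, at which 4 of the 4 values shown sit.

The compounds shown leave open whether swapping chloro for hydrogen changes inhibition at all.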